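Trading One Aryl Group on a Growth-Inhibiting Core

The source may hold more compounds than are shown below. What is called first, only, known or untested is meant among the compounds shown, and "the series" means these compounds.

In a functional assay on A498 cells (Homo sapiens) for cytotoxicity (on this read-out higher numbers stand for weaker inhibition of growth and lower numbers for stronger inhibition of growth), three compounds sharing one core have been tested. Compound 1 `COc1ccc(C2=C(c3cc(OC)c(OC)c(OC)c3)CC3CCCN3C2=O)cc1O` reads > 100000 nM as a limit of the assay, not as a number. Compound 3 `COc1ccc(C2=C(c3ccc(SC)cc3)CC3CCCN3C2=O)cc1OC` gives 8000 nM and compound 2 `CSc1ccc(C2=C(c3ccc(C)c(C)c3)C(=O)N3CCCC3C2)cc1` gives 300 nM as the lower of the two true numbers, a gap well beyond the scatter. Compound 4 `CSc1ccc(C2=C(c3ccc(O)cc3)C(=O)N3CCCC3C2)cc1` carries 4-hydroxyphenyl in place of 3,4-dimethylphenyl on a double-bonded ring carbon of compound 2 (4-hydroxyphenyl in place of 3,4-dimethylphenyl on a double-bonded ring carbon). Within the data shown here, no measured pair isolates this swap, so any forecast is loose. Compound 3 at 8000 nM shows that this core can read far higher than compound 2 does. The expected change is a 3.0-fold higher number from compound 2 to compound 4 (0.48 log units; beyond the scatter) toward weaker inhibition of growth. Compound 4 is expected at 900 nM within a range of 150 nM to 6000 nM in this estimate.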

Compound 4, concentration for 50% growth inhibition: > 100000 nM
Compound 4 gave a limit, no number; the forecaster's own chance of this, stated with the estimate: 7%; at least 110-fold (2.04 log units) between middle value and limit.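

In this assay, among these compounds, the first single swap that can be read at this ring carbon has a large effect: replacing 3,4-dimethylphenyl with 4-hydroxyphenyl gives an at least 330-fold higher number from compound 2 to compound 4 (2.52 log units; beyond the scatter) as the step. The value of compound 4 is a limit and not a number, so the step has only a lower bound: the limit of > 100000 nM in this assay, at which 2 of the 4 values shown sit. This one aryl group therefore separates a compound with a true reading from one without.

As far as these compounds go, whether the added hydroxyl or the lost methyl groups matter more stays open. Plain phenyl or 4-aminophenyl at this position would help to separate the two.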